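The compounds below may be only part of what the source reports. "The series", "measured", "known", "first", "only" and "open" are said of these compounds alone.

Measured so far in a functional assay on HeLa cells (Homo sapiens) for antiproliferative activity, read by MTT assay, with a stated time of 72 h; a lower number here means a stronger inhibitor, a higher number a weaker inhibitor:
compound 1 `COc1ncc(-c2ccc3c(c2)N(c2ccc(C)cc2)C(=O)CO3)cc1NS(=O)(=O)c1ccc(F)cc1` — compound 1 gives 4650 nM;
compound 2 `COc1ncc(-c2ccc3c(c2)N(C2CCCCC2)C(=O)CO3)cc1NS(=O)(=O)c1ccc(F)cc1` — compound 2 gives 6100 nM;
compound 3 `COc1ncc(-c2ccc3c(c2)NC(=O)CO3)cc1NS(=O)(=O)c1ccc(F)cc1` — compound 3 gives 7110 nM.

Compound 3 sits together with the other two: the steps of a 1.5-fold higher number from compound 1 to compound 3 (0.18 log units; within the scatter) and a 1.2-fold higher number from compound 2 to compound 3 (0.07 log units; within the scatter) are both within the scatter, as is a 1.3-fold higher number from compound 1 to compound 2 (0.12 log units; within the scatter). Compound 4 `COc1ncc(-c2ccc3c(c2)N(C(C)C)C(=O)CO3)cc1NS(=O)(=O)c1ccc(F)cc1` differs from compound 3 by isopropyl in place of hydrogen on an amide-type nitrogen in a ring. For the measured compounds named here, the steps that bear on this change are the two that also alter the group on that nitrogen, a 1.5-fold higher number from compound 1 to compound 3 (0.18 log units; within the scatter) and a 1.2-fold higher number from compound 2 to compound 3 (0.07 log units; within the scatter); in each a larger group gave way to hydrogen without a move beyond the scatter. Putting a small alkyl group back is therefore expected to give only a slight step toward a lower number, a 1.2-fold lower number from compound 3 to compound 4 (0.07 log units; within the scatter), within the scatter. Compound 4 is estimated at 6000 nM, with a range of 3000 nM to 12000 nM.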

Compound 4, half-maximal inhibitory concentration: 2790 nM
Compound 4: middle estimate off by 2.2-fold (0.33 log units), on the high side; measured number below the stated range.
By their numbers in this assay, from the lowest: compounds 4, 1, 2 and 3 (each within the scatter of the next, the first and the last beyond it).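

In this assay this position is no longer flat: isopropyl on the amide-type nitrogen gives a 2.5-fold lower number from compound 3 to compound 4 (0.41 log units; beyond the scatter) and, in place of cyclohexyl, gives a 2.2-fold lower number from compound 2 to compound 4 (0.34 log units; beyond the scatter). Isopropyl in place of 4-methylphenyl stays within the scatter at a 1.7-fold lower number from compound 1 to compound 4 (0.22 log units; within the scatter), so compound 1 is not separated from compound 4, and only compound 2 and compound 3 are. Nothing measured here explains the change.

Open, as far as these compounds go, is how methyl, ethyl or a longer chain on this nitrogen would compare with isopropyl. Also open, from the compounds shown here alone, is how a chain ending in an amine or a carboxylic acid would compare.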